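The source may hold more compounds than are shown below. What is called first, only, known or untested is meant among the compounds shown, and "the series" means these compounds.

Measured compounds:

compound 1, `COc1cc(C(=O)N2CCC(O)C(C)C2)cc2nc(NCc3cccc(Cl)c3)oc12`: 25 nM
compound 2, `COc1cc(C(=O)N2CC[C@H](O)[C@@H](C)C2)cc2nc(NCc3cccc(Cl)c3)oc12`: 120 nM
compound 3, `COc1cc(C(=O)N2CCC(O)C(C)C2)cc2nc(NCc3cc(Cl)ccn3)oc12`: 190 nM

These three were tested in an assay on isolated protein for inhibition of thyroid hormone receptor beta (Homo sapiens), read by fluorescence, with a stated time of 30 min; on this read-out higher numbers stand for weaker inhibition and lower numbers for stronger inhibition. Among them compound 3 gives the highest number, 190 nM, although the gap to compound 2 is within the usual scatter, so the two cannot be ordered; the gap to compound 1 is clear.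

Compound 4, `COc1cc(C(=O)N2CCC(O)C(C)C2)cc2nc(NCc3cccc(Cl)n3)oc12`, has not yet been tested. It differs from compound 3 only at the chlorinated pyridine on the saturated chain carbon bound to a nitrogen on the aromatic ring: 6-chloropyridin-2-yl in place of 4-chloropyridin-2-yl on a saturated chain carbon bound to a nitrogen on an aromatic ring. The chlorine thus stays on the same pyridine ring but at a different spot.

Two measured steps exist. The step of a 4.8-fold higher number from compound 1 to compound 2 (0.68 log units; beyond the scatter) concerns the drawn ring stereochemistry and not the chlorinated ring; the evidence for it is the fact that one of compounds 1 and 2 is drawn with a defined configuration and the other without, at the place where they differ. The step of a 7.6-fold higher number from compound 1 to compound 3 (0.88 log units; beyond the scatter) is the one touching the same part of the molecule, and it shows that exchanging the chlorophenyl for a chloropyridine raised the number. Going by the values given here, no step compares two chloropyridines with the chlorine in different spots, so the present change has no direct precedent.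

The expected outcome is therefore a step of a 1.3-fold lower number from compound 3 to compound 4 (0.10 log units; within the scatter), that is, nothing clearly beyond the scatter in this assay. Compound 4 is estimated at 150 nM, in the range 40 nM to 550 nM.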

Compound 4, half-maximal inhibitory concentration: 580 nM
Compound 4: middle estimate off by 3.9-fold (0.59 log units), on the low side; the measured number lies above the stated range.
By their numbers in this assay, from the lowest: compound 1; then compounds 2 and 3 (each within the scatter of the next); then compound 4.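

In this assay, moving the chlorine around the same pyridine ring is not a neutral change, since 6-chloropyridin-2-yl in place of 4-chloropyridin-2-yl gives a clear step (a 3.1-fold higher number from compound 3 to compound 4 (0.48 log units; beyond the scatter)), even though the two groups have the same atoms. Going by these compounds alone, the earlier compounds showed only that a chloropyridine in place of 3-chlorophenyl raised the number, and the size of that rise now proves to depend on where the chlorine sits: the step with the 6-chloro group (a 23-fold higher number from compound 1 to compound 4 (1.37 log units; beyond the scatter)) is larger than the one with the 4-chloro group (a 7.6-fold higher number from compound 1 to compound 3 (0.88 log units; beyond the scatter)). Within the data shown here, the only evidence at hand concerns how the ring stereochemistry is drawn, so nothing here explains why the location of the chlorine matters.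

The compounds shown leave open whether the chlorine itself helps or hinders on this ring, which plain pyridin-2-yl or 6-methylpyridin-2-yl at the same place could test. They also leave open whether the step between the two chloropyridines would keep its size with the ring stereochemistry drawn as in compound 2.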